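A few compounds are considered here, and "the series" means these few. Any claim that something is new, unique, unknown or untested is made for them only; others in the source may bear on it.

Compound 1 `Cn1ccc(-c2cccc3c2CCC3c2ncc[nH]2)n1` was examined in a functional assay on CHO cells for agonist activity at Alpha-1D adrenergic receptor (Homo sapiens), read by FLIPR and calcium flux; on this read-out lower numbers stand for an effect already at smaller amounts and higher numbers for an effect only at larger amounts of compound. In this assay compound 1 gives only a limit, > 10000 nM, and no number. Compound 2 `CS(=O)(=O)Nc1cccc2c1CCCC2c1ncc[nH]1`, which carries a different substituent on the shared core, likewise returns only a limit in this assay, > 10000 nM; > 10000 nM; > 10000 nM (3 entries). On the numbers shown, compound 1 stands at the limit of > 10000 nM in this assay, at which 1 of the 2 values shown sits, so the two compounds cannot be set apart beyond what their limits show. Compound 3 `Cc1oncc1-c1cccc2c1CCC2c1ncc[nH]1` has not yet been measured in this assay. It differs from compound 1 in one place: 5-methyl-1,2-oxazol-4-yl in place of 1-methyl-1H-pyrazol-3-yl on an aromatic carbon. Within the data shown here, no measured step of this kind exists here. Compound 3 is therefore expected to behave much like compound 1. The expected step is a step that the limit leaves unreadable from compound 1 to compound 3, none beyond the scatter. Compound 3 is estimated at 15000 nM, within 3000 nM to 60000 nM, most likely once more reported only as a limit.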

Compound 3, half-maximal effective concentration: > 10000 nM
Compound 3: a limit, no number; the forecaster's own chance of this, stated with the estimate: 80%; the middle value is on the limit's open side.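

Among these compounds, compound 3, like compound 1, returns only a limit in this assay, so no step between the two can be read. The compounds shown leave open how 5-methyl-1,2-oxazol-4-yl and 1-methyl-1H-pyrazol-3-yl compare, with no single number among them: the limit of > 10000 nM in this assay, at which 2 of the 3 values shown sit.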